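The source may report more compounds than this note shows. Statements on the series, on what has been measured and on what is new or still open speak of the compounds shown alone.

Among the measured compounds shown here, compound 2 `O=C(CCl)Nc1ccc(S(=O)(=O)Oc2ccccc2I)cc1` gives the lower of the two numbers so far in a functional assay on MCF7 cells (Homo sapiens) for antiproliferative activity, read by sulforhodamine B assay, with a stated time of 48 h; a higher number here means a weaker inhibitor, a lower number a stronger inhibitor: compound 2 gives 2500 nM, while compound 1 `CCCC(=O)Nc1ccc(S(=O)(=O)Oc2ccccc2I)cc1` gives 9700 nM. For the measured compounds named here, the one step measured, a 3.9-fold lower number from compound 1 to compound 2 (0.59 log units; beyond the scatter), shows that the group on the saturated chain carbon bound to the carbonyl carbon matters. Compound 3 `O=C(CCCl)Nc1ccc(S(=O)(=O)Oc2ccccc2I)cc1` differs from compound 2 by chloromethyl in place of chloro on a saturated chain carbon bound to a carbonyl carbon, moving the chain partway back toward the longer one of compound 1. Going by the values given here, no measured step copies this change; a modest rise in this assay is expected. Compound 3 is expected to give 6000 nM, within 2500 nM to 15000 nM, a step of a 2.4-fold higher number from compound 2 to compound 3 (0.38 log units; beyond the scatter).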

Compound 3, half-maximal inhibitory concentration: 8900 nM
Compound 3: middle estimate off by 1.5-fold (0.17 log units), on the low side; the range from low to high includes it.
By their numbers in this assay, from the lowest: compound 2; then compounds 3 and 1 (each within the scatter of the next).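

In this assay, a chlorine on the chain is not enough by itself: (2-chloroethyl)carbonyl in place of (chloromethyl)carbonyl gives a 3.6-fold higher number from compound 2 to compound 3 (0.55 log units; beyond the scatter). Chloro in place of methyl on a saturated chain carbon, two bonds along the chain from a carbonyl carbon, gives a 1.1-fold lower number from compound 1 to compound 3 (0.04 log units; within the scatter), so at that place the swap makes no difference beyond the scatter. Nothing available explains why the two places differ. From the compounds shown here alone, it remains open whether bromo or an amine on the saturated chain carbon bound to a carbonyl carbon would keep the lower number, and what a longer chain ending in chloro would give.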